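Fluoro substitution on the fused ring of the nitrile series

This account rests on a few compounds, and the source may have more. Where it says the series, first, only, none or still open, it means among the compounds named here.

Compound 1, `N#Cc1cc(-c2nc3ccccc3s2)ccc1N`, is the reference point of this small set. In a functional assay on MDA-MB-468 cells (Homo sapiens) for inhibition, with a stated time of 72 h (on this read-out higher numbers stand for weaker inhibition of growth and lower numbers for stronger inhibition of growth), compound 1 gives 340 nM, the highest of the three numbers recorded. The two other measured compounds carry a fluoro group on the shared core and change the nitrile for a different group at the same time, so neither is a single-change neighbour of compound 1. Compound 2, `C#Cc1cc(-c2nc3c(F)cccc3s2)ccc1N`, gives 30 nM in this assay, and compound 3, `C#Cc1cc(-c2nc3ccc(F)cc3s2)ccc1N`, gives 23 nM; both of these numbers lie beyond the scatter from that of compound 1.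

The step under consideration goes from compound 1 to compound 4, `N#Cc1cc(-c2nc3c(F)cccc3s2)ccc1N`. The change is fluoro in place of hydrogen on an aromatic carbon; the new group sits on an aromatic carbon of the six-membered ring of carbon only, ortho to a fused ring. For the measured compounds named here, no single-change step of this kind has been measured in the set, and the difference between compound 1 and compounds 2 and 3 cannot be attributed to the fluoro group alone.

The expectation for compound 4 in this assay is therefore a small step, if any, towards stronger inhibition, a 1.5-fold lower number from compound 1 to compound 4 (0.17 log units; within the scatter), not clearly beyond the scatter. Compound 4 is estimated at 230 nM, with a range from 90 nM to 600 nM.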

Compound 4, concentration for 50% growth inhibition: 80 nM
For compound 4 the middle estimate is 2.9-fold (0.46 log units) above the measured one, outside the stated range (below it).
By their numbers in this assay, from the lowest: compounds 3 and 2 (each within the scatter of the next); then compound 4; then compound 1.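

In this assay, fluoro in place of hydrogen on an aromatic carbon, ortho to a fused ring, now has a single-change reading in the nitrile series (a 4.3-fold lower number from compound 1 to compound 4 (0.63 log units; beyond the scatter)), so this position accepts the fluoro group with a step towards stronger inhibition of growth that lies beyond the scatter. With the fluoro group held constant, cyano in place of ethynyl gives a step in the opposite direction (a 2.7-fold higher number from compound 2 to compound 4 (0.43 log units; beyond the scatter)), which is also beyond the scatter and shows that this exchange matters on its own. Compound 4 therefore stands between compound 1 and compound 2 by its printed values, and the large gap between those two compounds cannot be assigned to the fluoro group alone.

Still open, as far as these compounds go, is whether the placement of fluoro in compound 3 gives a similar step in the nitrile series, and whether a methoxy group or an amine at the carbon that carries fluoro in compound 4 would do the same. No supporting measurement explains either step.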